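A few compounds are considered here, and "the series" means these few. Any claim that something is new, unique, unknown or untested is made for them only; others in the source may bear on it.

Measured so far:
- compound 1 `COc1ccc(-c2cc3cccc(OC)c3nc2O)cc1`: 10000 nM
- compound 2 `COc1ccc(-c2cc3c(OC)cc(OC)cc3n(CC#N)c2=O)cc1`: 10000 nM

In a functional assay on T47D cells (Homo sapiens) for cytotoxicity, read by colorimetric assay and MTT assay (on this read-out higher numbers stand for weaker inhibition and lower numbers for stronger inhibition), compound 2 gives 10000 nM, level with compound 1 at 10000 nM. Compound 3 `COc1ccc(-c2cc3c(OC)cc(OC)cc3n(CC(=O)OCc3ccccc3)c2=O)cc1` differs from compound 2 by benzyloxycarbonyl in place of cyano on a saturated chain carbon bound to an aromatic nitrogen, with benzyloxycarbonyl in place of cyano on a saturated chain carbon bound to an aromatic nitrogen. Among the compounds with values here, no measured step between matched compounds is available, so the expectation rests on these two values and the structural change alone. The expected 1.7-fold lower number from compound 2 to compound 3 (0.22 log units; within the scatter) in this assay is small, towards stronger inhibition and hardly beyond the scatter. For compound 3 the estimated value is 6000 nM, with an expected range of 1500 nM to 15000 nM.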

Compound 3, half-maximal inhibitory concentration: 10000 nM
Compound 3: the middle estimate sits 1.7-fold (0.22 log units) below what was measured; the measured number falls inside the stated range.
By their numbers in this assay, from the lowest: compounds 1, 2 and 3 (each within the scatter of the next).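

In this assay, benzyloxycarbonyl in place of cyano on a saturated chain carbon bound to an aromatic nitrogen gives no change at the digits printed from compound 2 to compound 3 (within the scatter). Within the data shown here, this is the first matched step at this position, and it shows that adding a carbon-only aromatic ring and a carbonyl there leaves the number unchanged. No measurement shown here explains this result.

On these data alone, it remains open whether a carboxylic acid in place of the benzyl ester, an amine or a longer chain at this position would move the number. Changes elsewhere on the shared core also remain untested by any matched step.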